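Swapping methoxy for fluoro at the assay limit

A few compounds are considered here, and "the series" means these few. Any claim that something is new, unique, unknown or untested is made for them only; others in the source may bear on it.

Measured so far in a functional assay on SEM cells (Homo sapiens) for cytotoxicity, with a stated time of 72 h (on this read-out lower numbers stand for an effect already at smaller amounts and higher numbers for an effect only at larger amounts of compound), with each value only a limit
- Compound 1 `C=C[C@@](C)(/C=C/c1ccc(Nc2ccccc2)cc1)CCC=C(C)C` gives > 36600 nM as a limit
- Compound 2 `C=C[C@@](C)(/C=C/c1ccc(Nc2ccc(OC)cc2)cc1)CCC=C(C)C` gives > 36600 nM as a limit
- Compound 3 `C=C[C@@](C)(/C=C/c1ccc(Nc2ccc(OC)c(OC)c2)cc1)CCC=C(C)C` gives > 36600 nM as a limit

Compound 3 stands at > 36600 nM and that is a limit, not a number. The same holds across the series, with the limit of > 36600 nM in this assay, at which 3 of the 3 values shown sit, and no actual number among them.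

The next compound is compound 4 `C=C[C@@](C)(/C=C/c1ccc(Nc2ccc(OC)c(F)c2)cc1)CCC=C(C)C` which carries fluoro in place of methoxy on an aromatic carbon, ortho to a methoxy group and meta to a large group. Counted out, the change is fluoro in place of methoxy on an aromatic carbon and nothing else in the structure differs.

Within the data shown here, two measured steps bear on this change, as both also concern methoxy on an aromatic carbon. Among the measured compounds shown here, the first is a step that the two limits leave unreadable from compound 1 to compound 2 and the second is a step that the two limits leave unreadable from compound 2 to compound 3 and neither offers a size to carry forward. For the measured compounds named here, with no readable step as a guide, no step of known size or direction is expected in this assay and another limit is the likeliest report for compound 4. The expected outcome is a step that the limit leaves unreadable from compound 3 to compound 4 on present evidence. For compound 4 the estimated value is 40000 nM with an expected range from 15000 nM to 80000 nM if a number appears at all.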

Compound 4, half-maximal effective concentration: > 36600 nM
Compound 4: a limit, no number; the forecaster's own chance of this, stated with the estimate: 80%; the middle value does not contradict the limit.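

In this assay compound 4 gives > 36600 nM, which is a limit and not a number. No step between compound 1, compound 2, compound 3 and compound 4 can be read, as every value shown is a limit: the limit of > 36600 nM in this assay, at which 4 of the 4 values shown sit.

The compounds shown leave open whether hydrogen, methoxy or fluoro on these aromatic carbons makes any difference to the result.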